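The compounds below may be only part of what the source reports. "The series", "measured", "known", "first", "only" and "open" are said of these compounds alone.

Compound 1 `Cc1cn([C@@H]2C[C@H](O)[C@@H](CNC(=O)Nc3ccc(Br)cc3)O2)c(=O)[nH]c1=O` is one of three thymidine-derived ureas and thioureas whose cytotoxicity was examined in an ADME assay on MRC5 cells (Homo sapiens) for cytotoxicity; on this read-out higher numbers stand for lower toxicity in this test and lower numbers for higher toxicity in this test. In this assay compound 1 gives > 50000 nM, which is a limit of the assay rather than a measured number. Compound 2 `Cc1cn([C@@H]2C[C@H](O)[C@@H](CNC(=O)Nc3ccc(Cl)c(C(F)(F)F)c3)O2)c(=O)[nH]c1=O` also gives a limit in this assay, namely > 50000 nM. Compound 3 `Cc1cn([C@@H]2C[C@H](O)[C@@H](CNC(=S)Nc3ccc(OCc4ccccc4)cc3)O2)c(=O)[nH]c1=O` likewise reaches only a limit in this assay, > 50000 nM. Every value at hand therefore sits at the limit of > 50000 nM in this assay, at which 3 of the 3 values shown sit, so compound 1 stands where the whole set stands, with no number placing it above or below its companions.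

Compound 4 `Cc1cn([C@@H]2C[C@H](O)[C@@H](CNC(=O)Nc3ccc(OCc4ccc(Cl)cc4)cc3)O2)c(=O)[nH]c1=O` is not yet measured in this assay. Its structure differs from compound 1 in one place: (4-chlorobenzyl)oxy in place of bromo on an aromatic carbon. Among the measured compounds shown here, since each measured compound sits at the same limit, no step between them can be sized, and the (4-chlorobenzyl)oxy group of compound 3 is itself carried by a compound that sits at the limit.

Compound 4 is expected to remain at the limit, with a step that the limit leaves unreadable from compound 1 to compound 4 expected, none beyond the scatter. The estimated value of compound 4 in this assay is 60000 nM, within the range 30000 nM to 120000 nM.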

Compound 4, half-maximal cytotoxic concentration: > 50000 nM
Compound 4 was reported as a limit; the forecaster's own chance of this, stated with the estimate: 80%; the middle value is on the limit's open side.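

In this assay compound 4 gives > 50000 nM, which is a limit. Among the compounds shown here, compound 1 also stands at a limit, so no step between compound 1 and compound 4 can be read. The compounds shown leave open whether any of them differs from the others in cytotoxicity, and at what concentration any of them would reach the half-maximal effect.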